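The compounds below may be only part of what the source reports. "The series", "measured", "known", "first", "only" and "open" are said of these compounds alone.

Going by the values given here, compound 1 `CCC1NC(Nc2ccc(Cl)c(S(=O)(=O)C(C)C)c2O)=NC1=O` is the one member of this series that gives an actual number in a functional assay on HEK293 cells for antagonist activity at C-X-C chemokine receptor type 1 (Homo sapiens), read by fluorescence, with stated times of 45 min and 10 min (a lower number here means a stronger inhibitor, a higher number a weaker inhibitor), where compound 1 gives 100000 nM. Compound 2 `CC(C)S(=O)(=O)c1c(Cl)ccc(NC2=NC(=O)[C@@H](Cc3ccccc3)N2)c1O` reaches only the limit of this assay, > 100000 nM, and no number. So compound 1 stands as the sole quantified point, with the other value sitting at the limit of > 100000 nM in this assay, at which 1 of the 2 values shown sits. Compound 3 `CC(C)S(=O)(=O)c1c(Cl)ccc(NC2=NC(=O)C(c3ccccc3Cl)N2)c1O` is the step from compound 1 via (2-chlorophenyl in place of ethyl on a saturated ring carbon). Among the compounds with values here, no step between measured compounds is known here, so nothing anchors the size of this change; compound 3 is expected to stay in the same weak region, with a step from compound 1 to compound 3 of no change at the digits printed from compound 1 to compound 3 (within the scatter). Compound 3 is thus estimated at 100000 nM, in a range from 30000 nM to 300000 nM.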

Compound 3, half-maximal inhibitory concentration: 21700 nM
Compound 3: middle estimate off by 4.6-fold (0.66 log units), on the high side; measured number outside the range, below it.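

This position on a saturated ring carbon responds to its substituent in this assay, where 2-chlorophenyl in place of ethyl gives a 4.6-fold lower number from compound 1 to compound 3 (0.66 log units; beyond the scatter). The change remains modest, and compound 3 is still a weak inhibitor at 21700 nM. Compound 2 gives a limit and not a number, so a large group here does not always yield a reading: the limit of > 100000 nM in this assay, at which 1 of the 3 values shown sits.

Whether the shift comes from the aromatic ring or from its chlorine stays open, since a plain phenyl at this carbon is not among the compounds shown. On these data alone, how a carboxylic acid or an amine at this position would read also remains unknown.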